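Swapping a Ring Amine for an Open Chain Amine

The compounds below may be only part of what the source reports. "The series", "measured", "known", "first", "only" and "open" are said of these compounds alone.

For the measured compounds named here, compound 1 `O=c1[nH]c(-c2cccc3ccccc23)nc2ccc(N3CCCCC3)cc12` is the stronger of the two compounds measured so far. In an assay on isolated protein for inhibition of DNA topoisomerase 1 (Homo sapiens), with a stated time of 30 min, tested at 100 uM (a lower number here means a weaker effect, a higher number a stronger effect of the compound at the concentration tested), compound 1 gives 100%, the highest of the two numbers seen here. Going by the values given here, the only other measured compound, compound 2 `Cc1ccc2c(=O)[nH]c(-c3cccc(OC(F)(F)F)c3)nc2c1`, differs from compound 1 in more than one place, so no single step can be read between them. In this assay compound 2 gives 77.2%, a gap to compound 1 that lies beyond the usual scatter of such measurements.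

Compound 3 `CCN(CC)c1ccc2nc(-c3cccc4ccccc34)[nH]c(=O)c2c1` has not yet been measured. It is compound 1 with one change: diethylamino in place of piperidin-1-yl on an aromatic carbon. The group leaving and the group entering are of nearly the same size and each counts one hydrogen-bond acceptor and no donor.

Compound 3 is expected to give about 92% in this assay, with a likely range from 75% to 100%. The step of a number 8 percentage points lower from compound 1 to compound 3 (within the scatter) is expected to be small, at most a slight drop, since compound 1 already stands at 100% and the read-out cannot rise further.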

Compound 3, a percentage reported as inhibition, at one concentration (the size of the read-out at that concentration, not a potency): 90.4%
The estimate for compound 3 lay 1.6 percentage points above the measured number; measured number inside the range.
By their numbers in this assay, from the lowest: compound 2; then compounds 3 and 1 (each within the scatter of the next).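

In this assay, for the compounds shown here, the change from piperidin-1-yl to diethylamino gives a number 9.6 percentage points lower from compound 1 to compound 3 (within the scatter) and is the first direct reading of this position, as compound 2 differs from compound 1 in more than one place. On this aromatic carbon, then, the amine need not be closed into a ring for the read-out to stay high, though this holds only at the single concentration tested, where compound 1 gives 100% and the scale can go no further, so a real difference in potency between the two could stay hidden. Nothing at hand explains why the two groups read alike.

On these data alone, how far this freedom extends remains open: a smaller amine such as dimethylamino, a ring amine with a second hetero atom such as morpholin-4-yl, or a primary amine might or might not hold the read-out as well. Also open, as far as these compounds go, is whether any amine is needed here at all, which a plain hydrogen on this carbon would test, and how compound 1 and compound 3 compare at lower concentrations.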